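Benzyloxy acetophenones: nitro for chloro on the benzyl ring

The source may report more compounds than this note shows. Statements on the series, on what has been measured and on what is new or still open speak of the compounds shown alone.

Among the measured compounds shown here, compound 1 `CC(=O)c1cccc(OCc2cccc(Cl)c2)c1` holds the lowest of the two numbers so far: in an assay on isolated protein for inhibition of Amine oxidase [flavin-containing] B (Homo sapiens), read by Amplex Red, with a stated time of 15 min (a higher number here means a weaker inhibitor, a lower number a stronger inhibitor), compound 1 gives 34.2 nM. Its nearest neighbour, compound 2 `CC(=O)c1cccc(OCc2ccc(C(F)(F)F)cc2)c1`, gives 43.2 nM in this assay, a gap within the scatter, so the two cannot be ordered. Compound 3 `CC(=O)c1cccc(OCc2cccc([N+](=O)[O-])c2)c1` differs from compound 1 by nitro in place of chloro on an aromatic carbon. For the measured compounds named here, no measured pair shows this change, so only a small step is expected, a 1.5-fold higher number from compound 1 to compound 3 (0.16 log units; within the scatter), toward a slightly higher number, and within the scatter. Compound 3 is therefore estimated at 50 nM, between 20 nM and 150 nM.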

Compound 3, half-maximal inhibitory concentration: 114 nM
Compound 3: the middle estimate sits 2.3-fold (0.36 log units) below what was measured; measured number inside the range.
By their numbers in this assay, from the lowest: compounds 1 and 2 (each within the scatter of the next); then compound 3.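

In this assay, among the compounds shown here, nitro in place of chloro on this aromatic carbon gives a 3.3-fold higher number from compound 1 to compound 3 (0.52 log units; beyond the scatter) and so provides the first step beyond the scatter: the group at this position does register, though modestly. The earlier pair could not show this, since its two values could not be ordered. Nothing on hand accounts for the step.

From the compounds shown here alone, whether an amine, a nitrile or a methoxy group on this carbon would track compound 1 or compound 3 remains open. So does whether the same change elsewhere on the ring gives a step of similar size.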